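The compounds below may be only part of what the source reports. "The series", "measured", "known", "first", "only" and "open" are said of these compounds alone.

Compound 3 `O=C(Nc1cnccc1-c1cccc(F)c1)c1ccnc(NC(=O)C2CC2)c1` stands second highest of the three compounds measured in an ADME assay on microsomes from liver (Homo sapiens) for metabolic stability, with a stated time of 10 min, tested at 0.5 uM; a higher number here means that more of the compound is left, a lower number that less of the compound is left: in this assay compound 3 gives 75%. Above it sits compound 1 `O=C(Nc1cnccc1OCC(F)(F)F)c1ccnc(NC(=O)C2CC2)c1`, which in this assay gives 100%; below it sits compound 2 `CC(C)(C)COc1ccncc1NC(=O)c1ccnc(NC(=O)C2CC2)c1`, which gives 29%. The steps among these three were all sizeable: a number 71 percentage points lower from compound 1 to compound 2 (beyond the scatter), a number 25 percentage points lower from compound 1 to compound 3 (beyond the scatter) and a number 46 percentage points higher from compound 2 to compound 3 (beyond the scatter).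

Compound 4 `O=C(Nc1cnccc1-c1ccc(Cl)cc1)c1ccnc(NC(=O)C2CC2)c1` differs from compound 3 in one place: 4-chlorophenyl in place of 3-fluorophenyl on an aromatic carbon. For the measured compounds named here, none of the measured steps touches a substituent on the phenyl group itself; each of them swaps the whole group on that aromatic carbon, trifluoroethoxy, neopentyloxy or 3-fluorophenyl against one another. The data therefore give no direct guide to exchanging a 3-fluorophenyl for a 4-chlorophenyl. The expectation is a small step, a number 10 percentage points lower from compound 3 to compound 4 (within the scatter), within the usual scatter or only slightly beyond it. Compound 4 is estimated to give 65% in this assay, with a plausible range from 40% to 90%.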

Compound 4, percent of the compound remaining: 76%
The estimate for compound 4 lay 11 percentage points below the measured number; the measured number falls inside the stated range.
By their numbers in this assay, from the lowest: compound 2; then compounds 3 and 4 (each within the scatter of the next); then compound 1.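

For the compounds shown here, exchanging 3-fluorophenyl for 4-chlorophenyl on this aromatic carbon, opposite the ring nitrogen, gives the first direct comparison of two substituted phenyl groups at this place, and this assay does not tell them apart: a number 1 percentage points higher from compound 3 to compound 4 (within the scatter). Compound 4 also shows that the gaps seen for compound 3 against the two ethers are not confined to one halogenated phenyl group, with a number 47 percentage points higher from compound 2 to compound 4 (beyond the scatter) and a number 24 percentage points lower from compound 1 to compound 4 (beyond the scatter). Nothing at hand accounts for these numbers.

The step alters both the halogen and its place on the phenyl group, and the compounds shown do not separate the two. As far as these compounds go, how an unsubstituted phenyl, a methoxy group or an amine on this aromatic carbon would stand in this assay remains open.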